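Swapping the Outer Ring Group on a Shared Core

The source may hold more compounds than are shown below. What is called first, only, known or untested is meant among the compounds shown, and "the series" means these compounds.

Compound 1, `COc1cc(-n2cnc3ccc(-c4ccc(C)cc4F)cc32)cc(OC)c1OC`: 56 nM
Compound 2, `COc1cc(-n2cnc3ccc(-c4cc(F)ccc4F)cc32)cc(OC)c1OC`: 6420 nM
Compound 3, `COc1cc(-n2cnc3ccc(-c4ccccc4)cc32)cc(OC)c1OC`: 2290 nM

All three were tested in a functional assay on MCF7 cells (Homo sapiens) for antiproliferative activity, read by MTT assay, with a stated time of 72 h; a higher number here means a weaker inhibitor, a lower number a stronger inhibitor. Compound 1 gives the lowest number of the three, and the other two sit well above it: a 41-fold higher number from compound 1 to compound 3 (1.61 log units; beyond the scatter) and a 110-fold higher number from compound 1 to compound 2 (2.06 log units; beyond the scatter). Compound 4, `COc1cccc(-c2ccc3ncn(-c4cc(OC)c(OC)c(OC)c4)c3c2)c1`, differs from compound 1 in one place: 3-methoxyphenyl in place of 2-fluoro-4-methylphenyl on an aromatic carbon. Both measured steps away from compound 1 exchange this same outer group, and both produce a large rise in the number. A change of similar kind is therefore expected here, with a large rise in the number anticipated for compound 4, a 27-fold higher number from compound 1 to compound 4 (1.43 log units; beyond the scatter). The estimate for compound 4 in this assay is 1500 nM, with a range from 300 nM to 8000 nM.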

Compound 4, half-maximal inhibitory concentration: 1610 nM
Compound 4: middle estimate off by 1.1-fold (0.03 log units), on the low side, within the range that was stated.
By their numbers in this assay, from the lowest: compound 1; then compounds 4 and 3 (each within the scatter of the next); then compound 2.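

In this assay, a third replacement of the 2-fluoro-4-methylphenyl group also gives a much higher number (a 29-fold higher number from compound 1 to compound 4 (1.46 log units; beyond the scatter)), now with a methoxy-bearing ring entering rather than a fluorinated one. Methoxy in place of hydrogen on the plain phenyl ring gives no difference beyond the scatter (a 1.4-fold lower number from compound 3 to compound 4 (0.15 log units; within the scatter)), yet 3-methoxyphenyl gives a modestly lower number than 2,5-difluorophenyl (a 4.0-fold lower number from compound 2 to compound 4 (0.60 log units; beyond the scatter)). No measurement here explains these differences.

The compounds shown leave open whether the methyl or the fluorine of compound 1 matters more. As far as these compounds go, how an amine or a carboxylic acid on this ring would behave also remains open.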